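From Hydroxy to Iodo on the Benzoyl Ring

A few compounds are considered here, and "the series" means these few. Any claim that something is new, unique, unknown or untested is made for them only; others in the source may bear on it.

Measured in a functional assay on HepG2 cells (Homo sapiens) for cytotoxicity, with a stated time of 24 h; a higher number here means a weaker inhibitor, a lower number a stronger inhibitor:
Compound 1 `O=C(N/N=C/c1cc(I)cc(I)c1O)c1ccc(O)cc1`: 19200 nM
Compound 2 `O=C(N/N=C/c1cc(I)cc(I)c1O)c1ccc(Cl)cc1`: 14800 nM

Both compounds share the same core, a di-iodinated salicylaldehyde hydrazone, and differ only in the group on the far ring of the benzoyl part. Going by the values given here, compound 1 stands with the highest of the two numbers, but its only neighbour, compound 2, lies within the scatter of it, so no real order between them can be read.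

Compound 3 `O=C(N/N=C/c1cc(I)cc(I)c1O)c1ccc(I)cc1` differs from compound 1 by iodo in place of hydroxy on an aromatic carbon. Among the compounds with values here, the one measured step that speaks to this change is a 1.3-fold lower number from compound 1 to compound 2 (0.11 log units; within the scatter), where a different halogen took the place of the same hydroxy at the same position. That step stayed within the scatter, and iodo is, like chloro, a halogen without hydrogen-bond donors or acceptors, so no step beyond the scatter is expected here either, at most a slight drift to a lower number.

Compound 3 is therefore expected to show about 14000 nM in this assay, with a likely range from 6000 nM to 35000 nM. The expected step from compound 1 is a 1.4-fold lower number from compound 1 to compound 3 (0.14 log units; within the scatter), a change because the earlier swap gave only a 1.3-fold lower number from compound 1 to compound 2 (0.11 log units; within the scatter).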

Compound 3, half-maximal inhibitory concentration: 31800 nM
The estimate for compound 3 lay 2.3-fold (0.36 log units) below the measured number; the range from low to high includes it.
By their numbers in this assay, from the lowest: compounds 2, 1 and 3 (each within the scatter of the next, the first and the last beyond it).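

In this assay, putting iodo in place of hydroxy on this aromatic carbon gives a 1.7-fold higher number from compound 1 to compound 3 (0.22 log units; within the scatter), which stays within the scatter, so this pair cannot be told apart, just as the earlier swap of hydroxy for chloro could not be read as a real change. What the new compound adds is a first separation at this position: iodo in place of chloro gives a 2.1-fold higher number from compound 2 to compound 3 (0.33 log units; beyond the scatter), a modest step just beyond the scatter, so the two halogens here do not count as interchangeable, even though neither differs clearly from hydroxy. Nothing available beyond these cytotoxicity numbers accounts for that gap between chloro and iodo, and its origin stays unknown.

With only hydroxy, chloro and iodo shown at this position, it remains open whether an amine, a carboxylic acid or a longer chain on the same ring carbon would move the number well beyond the scatter. As far as these compounds go, it is also open whether bromo or fluoro would fall in line with chloro or with iodo, and whether the small gap between those two would hold up in repeated measurements.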